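Dropping the butyl from the amide of compound 2

This account rests on a few compounds, and the source may have more. Where it says the series, first, only, none or still open, it means among the compounds named here.

Going by the values given here, in a functional assay on A549 cells (Homo sapiens) for antiproliferative activity, read by CCK-8 assay, with a stated time of 72 h (a higher number here means a weaker inhibitor of growth, a lower number a stronger inhibitor of growth), compound 2 `CCCCNC(=O)c1ccc2c(ccn2-c2ncc3c(n2)N(c2ccn(C)n2)C(CC)C(=O)N3C)c1` gives 37300 nM and is the only compound with a number so far. Compound 1 `CCC1C(=O)N(C)c2cnc(-n3ccc4cc(F)ccc43)nc2N1c1ccn(C)n1` yields no number (recorded as "not active" (no number reported)). Compound 3 `CCC1C(=O)N(C)c2cnc(-n3ccc4cc(C(N)=O)ccc43)nc2N1c1ccn(C)n1` differs from compound 2 in one place (hydrogen in place of butyl on an amide-type nitrogen): hydrogen in place of butyl on an amide-type nitrogen, so butylcarbamoyl becomes carbamoyl. Among the compounds with values here, no step between measured compounds is available to size this change, so the only anchor is compound 2 at 37300 nM in this assay as the reference. No shift beyond the usual scatter is expected in either direction, and the estimated step is small (a 1.2-fold lower number from compound 2 to compound 3 (0.09 log units; within the scatter)). Compound 3 is estimated at 30000 nM (expected range 8000 nM to 100000 nM), and a result without a number remains possible.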

Compound 3, concentration for 50% growth inhibition: 39500 nM
Compound 3: middle estimate off by 1.3-fold (0.12 log units), on the low side; the measured number falls inside the stated range.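

In this assay, replacing butyl with hydrogen on the amide-type nitrogen gives a 1.1-fold higher number from compound 2 to compound 3 (0.02 log units; within the scatter), so this change does not separate the two compounds. At this position, the butyl chain is therefore not required for the level of growth inhibition seen with compound 2, and butylcarbamoyl and carbamoyl cannot be told apart in this cell read-out. No supporting data bear on why the two groups read alike.

Compound 1 is recorded without a number, so steps involving it cannot be read. As far as these compounds go, whether a longer chain or a benzyl group on the amide nitrogen, or a carboxylic acid or aminomethyl group in place of the carbamoyl, would move the number beyond the scatter remains open.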